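Chloro, isobutyl and methoxy in the acid series

The compounds below may be only part of what the source reports. "The series", "measured", "known", "first", "only" and "open" are said of these compounds alone.

Measured in a physicochemical assay for permeability, using PAMPA; a higher number here means that the compound crosses the layer faster, a lower number that the compound crosses the layer more slowly:
- compound 1 `O=C(O)CCn1c(=O)oc2cc(Cl)c(Cl)cc21`: 24 nm/s
- compound 2 `CC(C)Cc1cc2oc(=O)n(CCC(=O)O)c2cc1Cl`: < 10 nm/s (a limit)

Compound 2 stands at a limit of the assay, < 10 nm/s, and not at a number. Compound 3 `COc1cc2oc(=O)n(CCC(=O)O)c2cc1Cl` carries methoxy in place of isobutyl on an aromatic carbon. Within the data shown here, one measured step bears on this change: an at least 2.4-fold lower number from compound 1 to compound 2 (0.38 log units; beyond the scatter), beyond the scatter, with isobutyl in place of chloro. That step involves chloro rather than methoxy, so it is only a rough guide. With isobutyl leaving, a modest rise is expected. An estimated step of an at least 1.4-fold higher number from compound 2 to compound 3 (0.14 log units; that floor lies within the scatter) is expected in this assay. For compound 3 the estimated value is 14 nm/s, with an expected range of 7 nm/s to 32 nm/s.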

Compound 3, apparent permeability: < 3 nm/s
Compound 3 was reported as a limit; the forecaster's own chance of this, stated with the estimate: 35%; middle value at least 4.6-fold (0.66 log units) from the limit.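

In this assay compound 3 gives < 3 nm/s, which is a limit and not a number. Methoxy in place of chloro gives an at least 8.0-fold lower number from compound 1 to compound 3 (0.90 log units; beyond the scatter), so a fall at this position is no longer tied to isobutyl, and it also appears with a group of fewer heavy atoms that carries a hydrogen-bond acceptor. Compound 2 and compound 3 both stand at limits, and the step between them cannot be read.

As far as these compounds go, whether methoxy and isobutyl differ at all here stays open. Also open, from the compounds shown here alone, is how fluoro, an amine or a longer chain would read at this position.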